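The source may report more compounds than this note shows. Statements on the series, on what has been measured and on what is new or still open speak of the compounds shown alone.

Compound 1 `Cc1nc(C(NC(=O)C(=O)Nc2ccc(F)cc2)C2CCCCN2)sc1CCO`: 109000 nM
Compound 2 `Cc1nc(C(NC(=O)C(=O)Nc2ccc(Cl)cc2)C2CCCCN2C)sc1CCO`: 88000 nM
Compound 3 `Cc1nc(C(NC(=O)C(=O)Nc2ccc(Cl)cc2)C2CCCCN2)sc1CO`: > 108000 nM

All three compounds were examined in an ADME assay on MT2 cells (Homo sapiens) for cytotoxicity, read by XTT assay, with a stated time of 4 days; a higher number here means that more compound is tolerated, a lower number that less compound is tolerated. Compound 1 gives 109000 nM and compound 2 gives 88000 nM; the two values lie within the usual scatter of each other, so no order between them can be claimed. For compound 3 the assay reached only a limit, > 108000 nM, and no number is known for it. This is the limit of > 108000 nM in this assay, at which 1 of the 3 values shown sits, so compound 3 stands at the edge of what this assay can report, alongside compounds 1 and 2 which sit close beneath it.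

Compound 4 `Cc1nc(C(NC(=O)C(=O)Nc2ccc(F)c(Cl)c2)C2CCCCN2)sc1CO` differs from compound 3 in one place: 3-chloro-4-fluorophenyl in place of 4-chlorophenyl on an amide-type nitrogen. No step between measured compounds is shown, so nothing in the data tells how this change shifts this assay. With the three measured compounds all gathered near the limit, the expectation is a step of no size beyond the scatter, a number no higher from compound 3 to compound 4 (the limit leaves the size open). Compound 4 is therefore estimated at 108000 nM, within a range from 50000 nM to 220000 nM, and it is expected that this assay will most likely again report only a limit.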

Compound 4, half-maximal cytotoxic concentration: > 77800 nM
Compound 4 ended at the assay's limit (the forecaster's own chance of this, stated with the estimate: 70%); the middle value is on the limit's open side.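

In this assay compound 3 gives > 108000 nM as a limit. Within the data shown here, compound 4 gives > 77800 nM as a limit too, so no step between compound 3 and compound 4 can be read. The compounds shown leave open how 3-chloro-4-fluorophenyl in place of 4-chlorophenyl shifts the tolerated concentration.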